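A Methoxy Group Added to a Weak Antiproliferative Scaffold

The source may report more compounds than this note shows. Statements on the series, on what has been measured and on what is new or still open speak of the compounds shown alone.

Of the compounds shown here, three sharing one core have been tested in a functional assay on A549 cells (Homo sapiens) for antiproliferative activity, read by MTT assay, with a stated time of 72 h; a higher number here means a weaker inhibitor, a lower number a stronger inhibitor. Compound 1 `O=C1COc2ccc(-c3cccc(NS(=O)(=O)c4ccc(F)cc4)c3)cc2N1c1ccccc1` carries an unsubstituted phenyl on the amide nitrogen and a fluorophenyl sulfonamide on the pendant ring. In this assay compound 1 gives > 40000 nM, which is a limit of the assay rather than a measured number. Compound 2 `O=C1COc2ccc(-c3cnc4ccccc4c3)cc2N1c1ccccc1` replaces the sulfonamide-bearing ring with a different bicyclic aromatic ring. In this assay compound 2 also reaches only the limit > 40000 nM. Compound 3 `Cc1ccc(N2C(=O)COc3ccc(-c4cnc(Cl)c(NS(=O)(=O)c5ccc(F)cc5)c4)cc32)cc1` keeps the sulfonamide, puts a methyl on the amide-nitrogen phenyl and a chlorine on a pyridine ring, and in this assay compound 3 gives 30900 nM, a real number though a weak one. Compound 1 thus stands at the limit of > 40000 nM in this assay, at which 2 of the 3 values shown sit, so no ranking among the three can be drawn.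

Compound 4 `COc1ccc(N2C(=O)COc3ccc(-c4cccc(NS(=O)(=O)c5ccc(F)cc5)c4)cc32)cc1` is the unmeasured partner of compound 1. The change is methoxy in place of hydrogen on an aromatic carbon. Among the compounds with values here, no step between measured compounds is available to guide its size. Within the data shown here, compound 3, the only one with a number, gives 30900 nM, so a large gain is not expected. The expected step from compound 1 to compound 4 is a number no higher from compound 1 to compound 4 (the limit leaves the size open), within the scatter. Compound 4 is therefore expected to give about 40000 nM, between 15000 nM and 100000 nM.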

Compound 4, half-maximal inhibitory concentration: 38200 nM
Estimate against measurement, compound 4: 1.0-fold (0.02 log units) above, and the stated range covers the measured number.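

Going from phenyl to 4-methoxyphenyl gives an at least 1.0-fold lower number from compound 1 to compound 4 (0.01 log units; that floor lies within the scatter) in this assay, so this change shows no gain that stands clear of the usual scatter. The true size of the step remains unknown because one end of it is only a limit: the limit of > 40000 nM in this assay, at which 2 of the 4 values shown sit.

What is new is a measured number for a compound with the plain sulfonamide-bearing pendant ring: with methoxy on the aromatic carbon para to a large group, compound 4 gives 38200 nM, which is still weak.

The compounds shown leave open whether a different group at this same place, such as an amine, a carboxylic acid or a longer chain like butoxy, would move the number beyond the scatter. Within the data shown here, they also leave open what the same change from phenyl to 4-methoxyphenyl does when the starting compound has a measured number rather than a limit, which is the only kind of comparison that could give this step a definite size.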